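Swapping (pyridin-3-yl)amino for piperidin-1-yl on a carbonyl carbon

This account rests on a few compounds, and the source may have more. Where it says the series, first, only, none or still open, it means among the compounds named here.

Measured in an in vitro ADME assay on microsomes from liver (Homo sapiens) for pharmacokinetics, read by LC-MS, with a stated time of 10 min, tested at 1 uM; a lower number here means slower removal, a higher number faster removal of the compound:
- Compound 1 `CN1C[C@H](C(=O)Nc2ccccc2F)[C@@H](c2ccc(/C=C/C(=O)Nc3ccccc3N)cc2)C1`: 10 mL/min/kg
- Compound 2 `CN1C[C@H](C(=O)Nc2ccc(F)cc2F)[C@@H](c2ccc(/C=C/C(=O)Nc3ccccc3N)cc2)C1`: 12 mL/min/kg
- Compound 3 `CN1C[C@H](C(=O)Nc2cccnc2)[C@@H](c2ccc(/C=C/C(=O)Nc3ccccc3N)cc2)C1`: 10 mL/min/kg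

Clearance tells how quickly liver enzymes remove a compound. Compound 3 stands level with compound 1, and all three values lie within the scatter of one another, so these compounds cannot be told apart on this measure.

The next structure, compound 4 `CN1C[C@H](C(=O)N2CCCCC2)[C@@H](c2ccc(/C=C/C(=O)Nc3ccccc3N)cc2)C1`, differs from compound 3 at one place: piperidin-1-yl in place of (pyridin-3-yl)amino on a carbonyl carbon. Piperidin-1-yl comes in place of (pyridin-3-yl)amino on a carbonyl carbon, so a non-aromatic ring enters where an aromatic one stood.

Two measured steps changed the group at this same place: no change at the digits printed from compound 1 to compound 3 (within the scatter), and a 1.2-fold lower number from compound 2 to compound 3 (0.08 log units; within the scatter). A third step added a fluoro on an aromatic carbon: a 1.2-fold higher number from compound 1 to compound 2 (0.08 log units; within the scatter). All three were small, but every one of these compounds keeps an aromatic ring there, so they offer only limited guidance for this larger change. No step beyond the scatter is therefore expected in this assay, though a small rise is possible and the uncertainty is wide. The expected step is a 1.3-fold higher number from compound 3 to compound 4 (0.11 log units; within the scatter). Compound 4 is estimated at 13 mL/min/kg, with an expected range from 6 mL/min/kg to 30 mL/min/kg.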

Compound 4, clearance: 9 mL/min/kg
The estimate for compound 4 lay 1.4-fold (0.16 log units) above the measured number; the measured number falls inside the stated range.
By their numbers in this assay, from the lowest: compounds 4, 1, 3 and 2 (each within the scatter of the next).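

In this assay, among these compounds, the earlier compounds all carried an aromatic ring on an amide nitrogen, so they could not show what happens when that ring and the amide hydrogen are both lost. Compound 4 tests this with piperidin-1-yl on the carbonyl carbon, and each comparison stays small: a 1.1-fold lower number from compound 3 to compound 4 (0.05 log units; within the scatter), a 1.1-fold lower number from compound 1 to compound 4 (0.05 log units; within the scatter) and a 1.3-fold lower number from compound 2 to compound 4 (0.12 log units; within the scatter). Across these four compounds, clearance at this position therefore does not depend on an aromatic ring or a hydrogen-bond donor in this group, although no measurement here explains why the values stay so close.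

As far as these compounds go, it remains open whether any group on this carbonyl carbon can produce a step beyond the scatter, for example morpholin-4-yl, an open-chain diethylamino group or a carboxylic acid in place of the whole amide. These compounds also share the rest of their structure, so they cannot show whether this insensitivity would hold if another part of the molecule carried a different group, such as an ethyl group in place of the methyl on the ring nitrogen.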